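Moving the Pyridine Nitrogen on a Bis-phenol Core

The source may report more compounds than this note shows. Statements on the series, on what has been measured and on what is new or still open speak of the compounds shown alone.

Among the measured compounds shown here, in a functional assay on T47D cells (Homo sapiens) for cytotoxicity, read by CCK-8 assay (on this read-out lower numbers stand for stronger inhibition and higher numbers for weaker inhibition), compound 3 `Oc1ccc(-c2cc(-c3ccccn3)cc(-c3ccc(O)cc3)n2)cc1` gives 1040 nM, the lowest of the three numbers so far. Compound 2 `Oc1ccc(-c2cc(-c3ccoc3)cc(-c3ccc(O)cc3)n2)cc1` gives 3460 nM in this assay, and compound 1 `Oc1ccc(-c2cc(-c3ccco3)cc(-c3ccc(O)cc3)n2)cc1` gives 21100 nM. The measured steps run a 6.1-fold lower number from compound 1 to compound 2 (0.79 log units; beyond the scatter), a 20-fold lower number from compound 1 to compound 3 (1.31 log units; beyond the scatter) and a 3.3-fold lower number from compound 2 to compound 3 (0.52 log units; beyond the scatter). Compound 4 `Oc1ccc(-c2cc(-c3cccnc3)cc(-c3ccc(O)cc3)n2)cc1` carries pyridin-3-yl in place of pyridin-2-yl on an aromatic carbon. For the measured compounds named here, the only measured step that resembles this change is the shift from furan-2-yl to furan-3-yl, a 6.1-fold lower number from compound 1 to compound 2 (0.79 log units; beyond the scatter), which lowered the number modestly; no step yet compares the two pyridyl groups themselves. Given that compound 3 already sits at the low end, the account expects for compound 4 a step of a 1.6-fold lower number from compound 3 to compound 4 (0.20 log units; within the scatter) that is at most modest and towards a lower number, quite possibly within the scatter. The estimate for compound 4 in this assay is therefore 650 nM, with a range from 200 nM to 2200 nM, pending the measurement.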

Compound 4, half-maximal inhibitory concentration: 2030 nM
Compound 4: the middle estimate sits 3.1-fold (0.49 log units) below what was measured; measured number inside the range.
By their numbers in this assay, from the lowest: compounds 3, 4 and 2 (each within the scatter of the next, the first and the last beyond it); then compound 1.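

In this assay, among the compounds shown here, putting pyridin-3-yl in place of pyridin-2-yl gives a 2.0-fold higher number from compound 3 to compound 4 (0.29 log units; within the scatter) and so the place of the pyridine nitrogen, which no earlier pair compared, cannot be read as making a difference at this position. Pyridin-3-yl in place of furan-3-yl likewise gives a 1.7-fold lower number from compound 2 to compound 4 (0.23 log units; within the scatter) and so these two groups cannot be told apart here either, although compound 2 and compound 3 do stand apart. Pyridin-3-yl in place of furan-2-yl, by contrast, gives a 10-fold lower number from compound 1 to compound 4 (1.02 log units; beyond the scatter) and so furan-2-yl remains the one group clearly separated from compound 4.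

Nothing shown here gives a reason for these differences. Also open, as far as these compounds go, is how a pyridin-4-yl, a phenyl or a thiophene group, or an amine, would behave at this position, opposite the ring nitrogen.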